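Hydrogen in place of chloro: one step, read twice

This account rests on a few compounds, and the source may have more. Where it says the series, first, only, none or still open, it means among the compounds named here.

Compound 1, `O=C(CSC(=S)N[C@H]1CCOC1=O)Nc1ccc(Cl)cc1`, in a functional assay on EC9706 cells (Homo sapiens) for cytotoxicity, read by MTT assay, with a stated time of 72 h (on this read-out lower numbers stand for stronger inhibition and higher numbers for weaker inhibition), gives only a limit of the assay, > 128000 nM.
Compound 2, `O=C(CSC(=S)N[C@H]1CCOC1=O)Nc1ccc(Cl)cc1Cl`, in this assay likewise gives only a limit, > 128000 nM.
Compound 3, `O=C(CSC(=S)N[C@H]1CCOC1=O)Nc1ccc(C(=O)/C=C/c2ccc(Cl)cc2)cc1`, in this assay gives 38900 nM.

From compound 2 to compound 1 the change is hydrogen in place of chloro on an aromatic carbon. The step it made, a step that the two limits leave unreadable from compound 2 to compound 1, cannot be sized because of the limit of > 128000 nM in this assay, at which 2 of the 3 values shown sit. How the core of compound 3 differs from the core of compound 2 is not broken down here. Compound 4, `O=C(CSC(=S)N[C@H]1CCOC1=O)Nc1ccc(C(=O)/C=C/c2ccccc2)cc1`, has not been measured; it differs from compound 3 by hydrogen in place of chloro on an aromatic carbon. This is the same kind of change as the earlier one, not the same: there the place was ortho to a large group and meta to a chloro group, here it is para to a large group.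

With the earlier step unreadable, the expectation rests on compound 3 alone. Compound 4 is expected near compound 3, with an estimated step of a 1.3-fold higher number from compound 3 to compound 4 (0.11 log units; within the scatter), since compound 3 gives 38900 nM. The estimate for compound 4 in this assay is 50000 nM, expected to lie between 20000 nM and 128000 nM.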

Compound 4, half-maximal inhibitory concentration: 44900 nM
Compound 4: middle estimate off by 1.1-fold (0.05 log units), on the high side; the measured number falls inside the stated range.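

In this assay, hydrogen in place of chloro on the 4-chlorophenyl group is a 1.2-fold higher number from compound 3 to compound 4 (0.06 log units; within the scatter), which lies within the usual scatter, so this change leaves no readable difference on this core. This does not show that the change carries over from one core to another, since the same kind of change on the core of compound 2, at a different place on the ring, cannot be sized: the limit of > 128000 nM in this assay, at which 2 of the 4 values shown sit. A different change, (2-phenylethenyl)carbonyl in place of chloro on an aromatic carbon, is an at least 2.8-fold lower number from compound 1 to compound 4 (0.45 log units; beyond the scatter), beyond the scatter, so the one readable difference here comes with that larger group and not with the chloro.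

The compounds shown leave open what an amine or a carboxylic acid in place of the chloro of compound 3 would give in this assay. They also leave open whether hydrogen in place of chloro stays within the scatter on any other core that gives a number rather than a limit.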